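The source may report more compounds than this note shows. Statements on the series, on what has been measured and on what is new or still open speak of the compounds shown alone.

Measured so far:
- compound 1 `O=C(NC1CCC1)[C@H]1O[C@@H](n2cnc3c(NCc4cccc(I)c4)nc(Cl)nc32)[C@H](O)[C@@H]1O`: 18.2 nM
- compound 2 `O=C([C@H]1O[C@@H](n2cnc3c(NCc4cccc(I)c4)nc(Cl)nc32)[C@H](O)[C@@H]1O)N1CCOCC1`: 513 nM

In an assay on CHO cells for displacement of a labelled ligand from adenosine receptor A3 (Homo sapiens) (a lower number here means a stronger inhibitor, a higher number a weaker inhibitor), compound 2 gives the higher of the two numbers; the step of a 28-fold higher number from compound 1 to compound 2 (1.45 log units; beyond the scatter) is beyond the scatter. Compound 3 `O=C(NCc1cccc(C(F)(F)F)c1)[C@H]1O[C@@H](n2cnc3c(NCc4cccc(I)c4)nc(Cl)nc32)[C@H](O)[C@@H]1O` is not yet measured. It differs from compound 2 in one place: (3-(trifluoromethyl)benzyl)amino in place of morpholin-4-yl on a carbonyl carbon. Going by the values given here, the only measured step that bears on this, a 28-fold higher number from compound 1 to compound 2 (1.45 log units; beyond the scatter), shows that removing the cyclobutylamino (with its hydrogen-bond donor) for morpholin-4-yl cost much; restoring a donor-bearing amino group points the other way. Compound 3 is therefore expected to return towards compound 1, with an estimated 13-fold lower number from compound 2 to compound 3 (1.11 log units; beyond the scatter), giving about 40 nM (range 10 nM to 160 nM).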

Compound 3, inhibition constant: 355 nM
For compound 3 the middle estimate is 8.9-fold (0.95 log units) below the measured one; measured number above the stated range.
By their numbers in this assay, from the lowest: compound 1; then compounds 3 and 2 (each within the scatter of the next).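

In this assay, an amide hydrogen on this carbonyl carbon is not enough by itself to restore binding: a 1.4-fold lower number from compound 2 to compound 3 (0.16 log units; within the scatter) leaves (3-(trifluoromethyl)benzyl)amino and morpholin-4-yl level. On the amide-type nitrogen, a 20-fold higher number from compound 1 to compound 3 (1.29 log units; beyond the scatter) comes with 3-(trifluoromethyl)benzyl in place of cyclobutyl, so the group carried by that nitrogen matters as well as the hydrogen-bond donor. Nothing measured here explains this difference.

Still open, as far as these compounds go, is whether a plain benzyl group, without the trifluoromethyl, would read like compound 3. A cyclopentyl or methyl group on that nitrogen could show whether compound 1 keeps its place.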